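This account rests on a few compounds, and the source may have more. Where it says the series, first, only, none or still open, it means among the compounds named here.

Measured in a functional assay on KYSE-450 cells (Homo sapiens) for inhibition, read by MTT assay, with a stated time of 48 h; a lower number here means a stronger inhibitor, a higher number a weaker inhibitor:
- compound 1 `COCC(=O)N(Cc1ccc(OC)c(O)c1)c1cc(OC)c(OC)c(OC)c1`: 460 nM
- compound 2 `COC(=O)c1cc(CNc2cc(OC)c(OC)c(OC)c2)ccc1OC`: 41100 nM

Of these two compounds, compound 1 stands lowest at 460 nM, which makes it the stronger inhibitor, and the gap to compound 2 at 41100 nM lies well beyond the scatter of repeated measurements. The next compound to be tested is compound 3 `C/C=C/C=C/C(=O)N(Cc1ccc(OC)c(O)c1)c1cc(OC)c(OC)c(OC)c1`. It keeps the core of compound 1 and changes one place: penta-1,3-dien-1-yl in place of methoxymethyl on a carbonyl carbon. Here penta-1,3-dien-1-yl stands in place of methoxymethyl on a carbonyl carbon whose other neighbour is an amide-type nitrogen. Going by the values given here, no measured pair shows this change, so any expectation in this assay stays loose: a modest rise in the number is expected, possibly not beyond the scatter. The expected size of the change is a 2.0-fold higher number from compound 1 to compound 3 (0.29 log units; within the scatter). For compound 3 the estimate is 900 nM, with an expected range from 150 nM to 5000 nM.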

Compound 3, half-maximal inhibitory concentration: 180 nM
For compound 3 the middle estimate is 5.0-fold (0.70 log units) above the measured one, and the stated range covers the measured number.
By their numbers in this assay, from the lowest: compound 3; then compound 1; then compound 2.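

At the carbonyl carbon whose other neighbour is the amide-type nitrogen, the core of compound 1 tolerates a longer all-carbon chain. In this assay, penta-1,3-dien-1-yl in place of methoxymethyl gives a modest gain in inhibition (a 2.6-fold lower number from compound 1 to compound 3 (0.41 log units; beyond the scatter)), a step beyond the usual scatter. The hydrogen-bond acceptor counted in methoxymethyl is therefore not needed at this position to reach this level of inhibition, although no measurement here explains the gain.

This single swap adds carbon atoms, adds two double bonds and removes an oxygen all at once, so the compounds shown cannot say which of these differences matters. On these data alone, it also remains open how a saturated pentyl chain, a phenyl ring or an amine-bearing chain would fare at the same carbonyl carbon.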